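Replacing the Trifluorophenyl Group of Compound 2

A few compounds are considered here, and "the series" means these few. Any claim that something is new, unique, unknown or untested is made for them only; others in the source may bear on it.

Measured in a functional assay on K562 cells (Homo sapiens) for antiproliferative activity, with a stated time of 72 h; on this read-out higher numbers stand for weaker inhibition and lower numbers for stronger inhibition:
Compound 1 `COc1ccccc1CNc1ncnc2c1ncn2[C@@H]1O[C@H](CO)[C@@H](O)[C@H]1O`: 89000 nM
Compound 2 `OC[C@H]1O[C@@H](n2cnc3c(NCc4c(F)ccc(F)c4F)ncnc32)[C@H](O)[C@@H]1O`: > 166000 nM (a limit, not a number)

From the compounds shown here alone, compound 2 stands only at the limit of > 166000 nM in this assay, at which 1 of the 2 values shown sits, so its exact position is unknown. Compound 3 `Cc1cccc(CNc2ncnc3c2ncn3[C@@H]2O[C@H](CO)[C@@H](O)[C@H]2O)c1O` differs from compound 2 in one place: 2-hydroxy-3-methylphenyl in place of 2,3,6-trifluorophenyl on a saturated chain carbon bound to a nitrogen on an aromatic ring. Among the measured compounds shown here, the single measured step that bears on this change is an at least 1.8-fold higher number from compound 1 to compound 2 (0.27 log units; that floor lies within the scatter), and its floor lies within the scatter, which makes it a weak guide. It does involve the same 2,3,6-trifluorophenyl group. Compound 1, with 2-methoxyphenyl at that place, gives 89000 nM, and on this one comparison a modest move to a lower number is expected in this assay. The expected step is an at least 2.2-fold lower number from compound 2 to compound 3 (0.34 log units; beyond the scatter). For compound 3 the estimated value is 75000 nM, with an expected range of 22000 nM to 170000 nM.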

Compound 3, half-maximal inhibitory concentration: 18000 nM
Estimate against measurement, compound 3: 4.2-fold (0.62 log units) above; measured number below the stated range.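

In this assay, the group at this position makes a clearer difference than the earlier pair could show: 2-hydroxy-3-methylphenyl in place of 2,3,6-trifluorophenyl gives an at least 9.2-fold lower number from compound 2 to compound 3 (0.96 log units; beyond the scatter). The same group also reads lower than the 2-methoxyphenyl of compound 1, with a 4.9-fold lower number from compound 1 to compound 3 (0.69 log units; beyond the scatter), a measured step beyond the scatter, whereas the earlier comparison gave only a floor within it. The step from the trifluorophenyl group is itself only a floor, as compound 2 carries a limit and not a number: the limit of > 166000 nM in this assay, at which 1 of the 3 values shown sits.

The compounds shown do not separate the hydroxyl from the methyl within 2-hydroxy-3-methylphenyl, so it stays open which of the two carries the step. From the compounds shown here alone, it also stays open how an amine in place of that hydroxyl would read in this assay.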